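Swapping the aryl on the triazole of a spiro scaffold

The source may hold more compounds than are shown below. What is called first, only, known or untested is meant among the compounds shown, and "the series" means these compounds.

Among the compounds with values here, compound 2 `N#CC1=C(N)Oc2c(N)cc3nc4ccccc4nc3c2C12C(=O)N(Cc1cnnn1-c1ccccc1Cl)c1ccccc12` holds the only number in a functional assay on MCF7 cells (Homo sapiens) for antiproliferative activity, read by MTT assay, with a stated time of 48 h (a higher number here means a weaker inhibitor, a lower number a stronger inhibitor), where compound 2 gives 34400 nM. Compound 1 `Cc1ccc(-n2nncc2CN2C(=O)C3(C(C#N)=C(N)Oc4c3c3nc5ccccc5nc3c3ccccc43)c3ccccc32)cc1C` returns > 50000 nM in this assay, a limit rather than a number. Within the data shown here, that leaves the limit of > 50000 nM in this assay, at which 1 of the 2 values shown sits, as the sole other reading. Compound 3 `Cc1ccc(-n2nncc2CN2C(=O)C3(C(C#N)=C(N)Oc4c(N)cc5nc6ccccc6nc5c43)c3ccccc32)cc1C` awaits measurement; it differs from compound 2 by 3,4-dimethylphenyl in place of 2-chlorophenyl on an aromatic nitrogen. Among the measured compounds shown here, with no measured pair sharing this change, the expected 1.2-fold higher number from compound 2 to compound 3 (0.07 log units; within the scatter) is small, within the scatter or drifting a little toward weaker. For compound 3 the estimated result is 40000 nM, with a range of 15000 nM to 100000 nM.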

Compound 3, half-maximal inhibitory concentration: > 50000 nM
Compound 3: a limit, no number; the forecaster's own chance of this, stated with the estimate: 40%; at least 1.2-fold (0.09 log units) between middle value and limit.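

Compound 3 reads as a limit in this assay, not a number. From the compounds shown here alone, on this aromatic nitrogen, 3,4-dimethylphenyl in place of 2-chlorophenyl therefore gives only a floor, an at least 1.4-fold higher number from compound 2 to compound 3 (0.16 log units; that floor lies within the scatter), so the true size of the change stays unknown and could lie within the scatter or well beyond it. The values now gather at one limit: the limit of > 50000 nM in this assay, at which 2 of the 3 values shown sit.

Going by these compounds, what an unsubstituted phenyl, a 4-methoxyphenyl or a chain ending in an amine would do on this nitrogen stays open. So does whether any group there gives a reading far stronger than that of compound 2.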